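Isomeric bicyclic urea partners at the vanilloid channel

The source may report more compounds than this note shows. Statements on the series, on what has been measured and on what is new or still open speak of the compounds shown alone.

Within the data shown here, compound 1 `CC1CCN(c2nc(C(F)(F)F)ccc2CNC(=O)Nc2cccc3c(=O)[nH]ccc23)CC1` is the only member of this set with a numerical read-out: in an assay on CHO cells for agonist activity at transient receptor potential cation channel subfamily V member 1 (Homo sapiens) (on this read-out higher numbers stand for an effect only at larger amounts of compound and lower numbers for an effect already at smaller amounts), compound 1 gives 9.59 nM. Two rearrangements of the same bicyclic urea partner return no number. Compound 2 `CC1CCN(c2nc(C(F)(F)F)ccc2CNC(=O)Nc2cccc3c2ccc(=O)n3C)CC1` is reported in this assay as "not active" (no number reported), and compound 3 `CC1CCN(c2nc(C(F)(F)F)ccc2CNC(=O)Nc2cccc3ccc(=O)[nH]c23)CC1` is reported in this assay as "not active" (no number reported). Among the measured compounds shown here, no step in size can be stated from compound 1 to either of them; the values only show that one arrangement gives a measurable effect and the other two do not.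

Compound 4 `CC1CCN(c2nc(C(F)(F)F)ccc2CNC(=O)Nc2cccc3cc[nH]c(=O)c23)CC1` is a further rearrangement of the same atoms. Against compound 1 the change is a group of 11 heavy atoms (9 carbon, 1 nitrogen, 1 oxygen; one six-membered aromatic ring of carbon only, one six-membered aromatic ring with 1 hetero atom) in place of a group of 11 heavy atoms (9 carbon, 1 nitrogen, 1 oxygen; one six-membered aromatic ring of carbon only, one six-membered aromatic ring with 1 hetero atom), on an amide-type nitrogen, a group of 11 heavy atoms (9 carbon, 1 nitrogen, 1 oxygen; one six-membered aromatic ring of carbon only, one six-membered aromatic ring with 1 hetero atom) in place of a group of 11 heavy atoms (9 carbon, 1 nitrogen, 1 oxygen; one six-membered aromatic ring of carbon only, one six-membered aromatic ring with 1 hetero atom), on an amide-type nitrogen. For the measured compounds named here, no measured pair of this kind exists, so the expected direction rests on the outcome that compound 3 shows "not active" (no number reported) and compound 2 shows "not active" (no number reported). A weakening beyond the scatter is expected for a 16-fold higher number from compound 1 to compound 4 (1.19 log units; beyond the scatter), with a real chance of no number at all. Compound 4 is estimated at 150 nM in this assay, within 15 nM to 3000 nM.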

Compound 4, half-maximal effective concentration: "not active" (no number reported)
The entry for compound 4 holds no number; the estimate stays without a comparison.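

Among these compounds, compound 4 is reported as "not active" (no number reported) in this assay, so no step from compound 1 to compound 4 can be read. The compounds shown leave open how far compound 2, compound 3 and compound 4 lie from compound 1. No supporting data bear on this outcome.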